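The source may report more compounds than this note shows. Statements on the series, on what has been measured and on what is new or still open speak of the compounds shown alone.

Measured compounds in a functional assay on A549 cells (Homo sapiens) for antiproliferative activity, read by MTT assay, with a stated time of 48 h; on this read-out lower numbers stand for stronger inhibition and higher numbers for weaker inhibition:
- compound 1, `CC(C)CCC1(O)C(=O)Nc2ccc(Nc3ccc(F)cc3)cc21`: 5700 nM
- compound 2, `CCCCCCC1(O)C(=O)Nc2ccc(Nc3ccc(F)cc3)cc21`: 12000 nM
- compound 3, `CC(C)CCC1(O)C(=O)Nc2ccc(Nc3ccc(Cl)cc3)cc21`: 2700 nM

Three compounds share one scaffold and differ at two places. Compound 1 and compound 2 differ at the chain: butyl in place of isopropyl on a saturated chain carbon, two bonds along the chain from a saturated ring carbon. Across this assay that change gave a 2.1-fold higher number from compound 1 to compound 2 (0.32 log units; beyond the scatter). Compound 1 and compound 3 differ on the aromatic ring instead: chloro in place of fluoro on an aromatic carbon. That change gave a 2.1-fold lower number from compound 1 to compound 3 (0.32 log units; beyond the scatter), and compound 3 stands with the lowest number of the three.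

Compound 4, `CCCCCCC1(O)C(=O)Nc2ccc(Nc3ccc(Cl)cc3)cc21`, has not yet been measured in this assay. It is related to compound 3 by butyl in place of isopropyl on a saturated chain carbon, two bonds along the chain from a saturated ring carbon. This is the same change that separates compound 2 from compound 1, made at the same place; the two cores differ only in the way already described for compound 1 and compound 3, namely (chloro in place of fluoro on an aromatic carbon). Among the compounds shown, the chain change occurs twice in all, once measured and once pending.

Among the compounds with values here, the one measured example of this change, a 2.1-fold higher number from compound 1 to compound 2 (0.32 log units; beyond the scatter), is the only guide available, so the step from compound 3 to compound 4 is expected to be of similar size, roughly a 2.1-fold higher number from compound 3 to compound 4 (0.32 log units; beyond the scatter). Going by these compounds, the estimate rests on that single step and on nothing else; whether the chain change behaves the same way on the core of compound 3 is unknown. Compound 4 is therefore estimated at 5700 nM, with a plausible range from 2700 nM to 12000 nM.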

Compound 4, half-maximal inhibitory concentration: 5400 nM
For compound 4 the middle estimate is 1.1-fold (0.02 log units) above the measured one; low and high end bracket the measured number.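

On the chloro-bearing core, the chain change in this assay gives a 2.0-fold higher number from compound 3 to compound 4 (0.30 log units; within the scatter), and this agrees with the earlier step on the fluoro-bearing core: the same change on two cores in this assay, a 2.1-fold higher number (0.32 log units; beyond the scatter) from compound 1 to compound 2 and a 2.0-fold higher number (0.30 log units; within the scatter) from compound 3 to compound 4, 1.1-fold (0.02 log units) apart, within the scatter of two such steps

The halogen change, read with butyl in place of isopropyl on the chain, gives a 2.2-fold lower number from compound 2 to compound 4 (0.35 log units; beyond the scatter), and it also agrees with its earlier counterpart: the same change on two cores in this assay, a 2.1-fold lower number (0.32 log units; beyond the scatter) from compound 1 to compound 3 and a 2.2-fold lower number (0.35 log units; beyond the scatter) from compound 2 to compound 4, 1.1-fold (0.02 log units) apart, within the scatter of two such steps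

Within these four compounds, each change therefore carries from one core to the other at about the same size, so the two changes appear to act independently of each other here; however, this rests on only one pair of steps per change, in a single cell line, and it does not show that either change would carry over in the same way to other cores or other groups, nor does it show why the steps match.

The compounds shown leave open whether the same agreement would hold for other groups on the aromatic ring, such as bromo, methoxy or trifluoromethyl, or for a shorter chain, a longer chain or a chain ending in an amine or a carboxylic acid. They also leave open how these steps would read in cell lines other than A549.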